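The compounds below may be only part of what the source reports. "The series", "measured", "known", "first", "only" and "open" are said of these compounds alone.

Values measured so far in a physicochemical assay for lipophilicity, read by HPLC, measured as chromatographic lipophilicity, at pH 7.4; a lower number here means a more polar compound, a higher number a more lipophilic compound:
compound 1 `O=C(c1ccccc1)N1CCC(C(=O)N2N=CCC2c2ccccc2)CC1` at 4.4
compound 2 `O=C(C1CCCC1)N1N=CCC1c1ccccc1` at 5.4
compound 3 `CC(C)C(=O)N1N=CCC1c1ccccc1` at 4.4

Compound 3 sits level with compound 1 at 4.4 and the two share the lowest number of the three. Compound 2 stands apart at 5.4 with a number higher than either, beyond the scatter.

Compound 4 `O=C(C1CCCCC1)N1N=CCC1c1ccccc1` has yet to be measured. It differs from compound 3 in one place, with cyclohexyl in place of isopropyl on a carbonyl carbon whose other neighbour is an amide-type nitrogen in a ring cyclohexyl in place of isopropyl on a carbonyl carbon and nothing else altered.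

Among the compounds with values here, only one measured step bears on this change, namely a number 1.00 log units lower from compound 2 to compound 3 (beyond the scatter) with isopropyl in place of cyclopentyl on a carbonyl carbon. Within the data shown here, the new change runs the other way, from isopropyl to a ring of carbon only, but cyclohexyl itself appears in no measured compound, so the evidence is a single, indirect step. Read in reverse, that step suggests an expected rise of similar size or slightly more. The expected size is a number 1.30 log units higher from compound 3 to compound 4 (beyond the scatter) on this reading. The estimate for compound 4 is 5.7 with an expected range from 5.2 to 6.2 in this assay once measured.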

Compound 4, distribution coefficient: 5.9
Compound 4: the middle estimate sits 0.20 log units below what was measured; the range from low to high includes it.
By their numbers in this assay, from the lowest: compounds 1 and 3 (each within the scatter of the next); then compound 2; then compound 4.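

In this assay, within the data shown here, the position on a carbonyl carbon whose other neighbour is an amide-type nitrogen in a ring proves more responsive than the single earlier step could show, with cyclohexyl in place of isopropyl giving a number 1.50 log units higher from compound 3 to compound 4 (beyond the scatter) on the shared core. The earlier compounds shown here had only set isopropyl against cyclopentyl, and they left unknown whether the number would keep climbing past the cyclopentyl compound; cyclohexyl in place of cyclopentyl now gives a number 0.50 log units higher from compound 2 to compound 4 (beyond the scatter) and so shows that it does. Among these three compounds, which differ only at this place, the order therefore runs from isopropyl through cyclopentyl to cyclohexyl, each separated from the next by more than the scatter, and no compound among them goes against it.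

On these data alone, compounds 2, 3 and 4 carry only carbon groups here, so how a longer open chain, a phenyl ring, an amine or a carboxylic acid on this carbonyl carbon would read stays open. Nothing shown offers any measurement that accounts for the size of these steps.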